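The source may hold more compounds than are shown below. What is called first, only, known or untested is meant among the compounds shown, and "the series" means these compounds.

Measured so far in an assay on isolated protein for inhibition of lysine-specific demethylase 5C (Homo sapiens), read by AlphaScreen, with stated times of 15 min and 20 min; a lower number here means a stronger inhibitor, a higher number a weaker inhibitor:
Compound 2 `O=c1[nH]cnc2c(-c3cscn3)nccc12`: 830 nM
Compound 1 `Cc1nc(-c2cc(C(=O)O)ccn2)cs1`: 1700 nM

Compound 2 holds the lowest number of the two, and its gap to compound 1 lies beyond the scatter of this assay. Compound 3 `Nc1nc(-c2nccc3c(=O)[nH]cnc23)cs1` is not yet measured. It differs from compound 2 by amino in place of hydrogen on an aromatic carbon. Within the data shown here, no step of this kind has been measured among the compounds here, so the size of the change in this assay is open. The amino group on the five-membered aromatic ring is expected to leave the number near that of compound 2 or move it somewhat lower, an estimated step of a 1.4-fold lower number from compound 2 to compound 3 (0.14 log units; within the scatter). Compound 3 is expected to give 600 nM in this assay, within 150 nM to 2500 nM.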

Compound 3, half-maximal inhibitory concentration: 331 nM
The estimate for compound 3 lay 1.8-fold (0.26 log units) above the measured number, within the range that was stated.
By their numbers in this assay, from the lowest: compound 3; then compound 2; then compound 1.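

Amino in place of hydrogen on an aromatic carbon of the five-membered aromatic ring, next to the ring nitrogen and next to the ring sulfur, gives a 2.5-fold lower number from compound 2 to compound 3 (0.40 log units; beyond the scatter) in this assay and is the first single-place step in the series. This position therefore takes a group larger than hydrogen on the shared core with no loss, and the number moves beyond the scatter. No available evidence bears on the reason for this step.

Going by these compounds, whether a methylamino group, an acetamide or a hydroxyl at this position would keep the lower number remains open.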